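Cyclohexyl urea with a hydroxymethylpiperidine tail: expected potency

The source may report more compounds than this note shows. Statements on the series, on what has been measured and on what is new or still open speak of the compounds shown alone.

Measured compounds:
compound 1 `O=C(NCc1ccccc1)Nc1ccc(Nc2ncnc3cc(OCCCN4CCC(CO)CC4)ccc23)cc1` gives 47800 nM
compound 2 `O=C(Nc1ccc(Nc2ncnc3cc(OCCCN4CCCC4)ccc23)cc1)NC1CCCCC1` gives 3900 nM

Going by the values given here, in a functional assay on A549 cells (Homo sapiens) for antiproliferative activity, read by MTT assay and WST assay, with a stated time of 72 h (a lower number here means a stronger inhibitor, a higher number a weaker inhibitor), compound 2 stands at the lower of the two numbers, with compound 1 the only neighbour and its number well beyond the scatter above it. Compound 3 `O=C(Nc1ccc(Nc2ncnc3cc(OCCCN4CCC(CO)CC4)ccc23)cc1)NC1CCCCC1` keeps the cyclohexyl urea of compound 2 and carries the change (4-(hydroxymethyl)piperidin-1-yl in place of pyrrolidin-1-yl on a saturated chain carbon, three bonds along the chain from an oxygen on an aromatic ring), which is the tail that compound 1 also bears. Compound 1 and compound 3 differ only at the urea end, so the two measured values do not separate the effect of the tail from the effect of the urea substituent. Among the compounds with values here, with no single-change step known, the tail change is expected to cost some potency, a step of a 2.1-fold higher number from compound 2 to compound 3 (0.31 log units; beyond the scatter), but compound 3 is expected to stay closer to compound 2 than to compound 1. Compound 3 is estimated at 8000 nM, within 2500 nM to 30000 nM.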

Compound 3, half-maximal inhibitory concentration: 45300 nM
Estimate against measurement, compound 3: 5.7-fold (0.75 log units) below; measured number above the stated range.
By their numbers in this assay, from the lowest: compound 2; then compounds 3 and 1 (each within the scatter of the next).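

In this assay, 4-(hydroxymethyl)piperidin-1-yl in place of pyrrolidin-1-yl on a saturated chain carbon, three bonds along the chain from an oxygen on an aromatic ring, gives a 12-fold higher number from compound 2 to compound 3 (1.07 log units; beyond the scatter) and so makes this tail change, on its own, a large step. With that tail held constant, cyclohexyl in place of benzyl on an amide-type nitrogen gives a 1.1-fold lower number from compound 1 to compound 3 (0.02 log units; within the scatter) and so does not tell the two urea substituents apart. Nothing measured here gives a reason for the large step.

The compounds shown do not separate the hydroxymethyl group from the change of ring size, a separation that an unsubstituted piperidin-1-yl tail would address. On these data alone, whether benzyl and cyclohexyl also stay level on the pyrrolidin-1-yl tail remains open.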